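Replacing 2,4-dichlorophenyl on a growth-inhibiting compound

A few compounds are considered here, and "the series" means these few. Any claim that something is new, unique, unknown or untested is made for them only; others in the source may bear on it.

Compound 1 `Cc1ccccc1/N=N/C(=N/NC(=O)c1cc(O)c(O)c(O)c1)c1ccccc1`: 32.7%
Compound 2 `O=C(N/N=C(/N=N/c1ccc(Cl)cc1Cl)c1ccccc1)c1cc(O)c(O)c(O)c1`: 12.1%

In an ADME assay on RAW264.7 cells (Mus musculus) for inhibition, read by MTT assay, with a stated time of 72 h, tested at 50 uM (on this read-out higher numbers stand for more inhibition of growth at the one concentration tested and lower numbers for less inhibition of growth), compound 2 stands lowest of the two measured compounds, below compound 1. Compound 3 `O=C(N/N=C(/N=N/c1ccccc1[N+](=O)[O-])c1ccccc1)c1cc(O)c(O)c(O)c1` differs from compound 2 on a double-bonded nitrogen: 2-nitrophenyl in place of 2,4-dichlorophenyl on a double-bonded nitrogen. Within the data shown here, only one measured step bears on this place, a number 20.6 percentage points lower from compound 1 to compound 2 (beyond the scatter). The 2-nitrophenyl group itself has not been measured, so that step gives only a rough guide. A rise somewhat smaller than that step is expected in this assay, and the expected change is a number 11.9 percentage points higher from compound 2 to compound 3 (beyond the scatter). The estimate for compound 3 is 24%, with a range from 10% to 40%.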

Compound 3, percent growth inhibition at one concentration: 2.11%
Compound 3: the middle estimate sits 21.9 percentage points above what was measured; measured number outside the range, below it.
By their numbers in this assay, from the lowest: compounds 3 and 2 (each within the scatter of the next); then compound 1.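

On a double-bonded nitrogen, 2-nitrophenyl in place of 2,4-dichlorophenyl gives a number 10 percentage points lower from compound 2 to compound 3 (within the scatter) in this assay and so cannot be told apart from it at this place. Nitro in place of methyl on an aromatic carbon gives a number 30.6 percentage points lower from compound 1 to compound 3 (beyond the scatter) and leaves compound 1 alone clear of the other two. Nothing available accounts for these results.

The compounds shown leave open whether a plain phenyl would stand with compound 1 or with compound 3. They also leave open what an amine or a carboxylic acid on this ring would give.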